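This account rests on a few compounds, and the source may have more. Where it says the series, first, only, none or still open, it means among the compounds named here.

Measured so far in an assay on L cells for inhibition of Protein-serine O-palmitoleoyltransferase porcupine (Mus musculus), read by reporter gene assay, with a stated time of 24 h; on this read-out higher numbers stand for an effect only at larger amounts of compound and lower numbers for an effect already at smaller amounts:
compound 1, `COc1ccc(-n2nc(C(=O)NCC(=O)Nc3nc4ccc(Cl)cc4s3)c3ccccc3c2=O)cc1`: 15 nM
compound 2, `COc1ccc(-n2c(SCC(=O)Nc3nc4ccc(C(F)(F)F)cc4s3)nc3c(c2=O)SCC3)cc1`: 100 nM
compound 3, `COc1ccccc1-n1c(SCC(=O)Nc2nc3ccc(C)cc3s2)nc2c(c1=O)SCC2`: 25 nM

Among these three numbers compound 3 stands second highest. Its nearest neighbour is compound 1, whose number lies within the usual scatter of that of compound 3, so the two cannot be ranked against each other. Compound 2 is furthest away: it gives a higher number than compound 3, and that gap lies beyond the scatter. Compound 2 and compound 3 differ in more than one place, so nothing further can be drawn from that pair.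

Compound 4, `COc1ccccc1-n1c(SCC(=O)Nc2nc3ccc(C(F)(F)F)cc3s2)nc2c(c1=O)SCC2`, has not been measured. It differs from compound 3 in a single place: trifluoromethyl in place of methyl on an aromatic carbon. Among the measured compounds shown here, no step between measured compounds that differ only in this way is available to size the change. The account therefore expects a small step in this assay, toward a higher number, at about the edge of the scatter. For compound 4 the estimated value is 50 nM, with a range from 15 nM to 160 nM. The step this estimate means, a 2.0-fold higher number from compound 3 to compound 4 (0.30 log units; within the scatter), is expected to be modest.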

Compound 4, half-maximal effective concentration: 30 nM
Beside the measured number, compound 4's estimate is 1.7-fold (0.22 log units) above it, and the stated range covers the measured number.
By their numbers in this assay, from the lowest: compounds 1, 3 and 4 (each within the scatter of the next); then compound 2.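

In this assay, among the compounds shown here, trifluoromethyl in place of methyl on this aromatic carbon gives a 1.2-fold higher number from compound 3 to compound 4 (0.08 log units; within the scatter), so the exchange of the single carbon for a group of four heavy atoms leaves compound 3 and compound 4 indistinguishable. Compound 4 also provides the first single-place link to compound 2: 2-methoxyphenyl in place of 4-methoxyphenyl on an aromatic nitrogen gives a 3.3-fold lower number from compound 2 to compound 4 (0.52 log units; beyond the scatter), a modest step beyond the scatter, so with trifluoromethyl held fixed the place of the methoxy group shows in this read-out. Nothing at hand accounts for either step.

From the compounds shown here alone, it remains open whether trifluoromethyl and methyl would also read alike with 4-methoxyphenyl on the aromatic nitrogen. Going by these compounds, how an amine, a carboxylic acid or a longer chain on that aromatic carbon would read also stays open.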